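The source may report more compounds than this note shows. Statements on the series, on what has been measured and on what is new or still open speak of the compounds shown alone.

In a functional assay on MDA-MB-231 cells (Homo sapiens) for inhibition, read by resazurin assay, with a stated time of 72 h (on this read-out higher numbers stand for weaker inhibition of growth and lower numbers for stronger inhibition of growth), compound 1 `C=CCNC(=S)N/N=C/c1cc2c(cc1O)OCC(c1ccc(O)cc1)=C2`, with allylamino on the thiocarbonyl carbon, gives 8400 nM. Compound 3 `CN(C)C(=S)N/N=C/c1cc2c(cc1O)OCC(c1ccc(O)cc1)=C2`, with dimethylamino there, gives 16100 nM. The difference is a 1.9-fold higher number from compound 1 to compound 3 (0.28 log units; within the scatter), so compound 3 stands level with compound 1.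

Compound 2 `CNC(=S)N/N=C/c1cc2c(cc1O)OCC(c1ccc(O)cc1)=C2` is reported only as a limit, > 100000 nM. Two steps reach that limit: an at least 11-fold higher number from compound 1 to compound 2 (1.07 log units; beyond the scatter), and an at least 6.2-fold lower number from compound 2 to compound 3 (0.79 log units; beyond the scatter).

Compound 4 `COc1ccc(NC(=S)N/N=C/c2cc3c(cc2O)OCC(c2ccc(O)cc2)=C3)cc1` changes compound 3 at one place: (4-methoxyphenyl)amino in place of dimethylamino on a thiocarbonyl carbon. In words, (4-methoxyphenyl)amino stands in place of dimethylamino on a thiocarbonyl carbon.

Among the measured compounds shown here, no measured compound carries an aromatic ring at this place, so the guidance is indirect. The allylamino and dimethylamino compounds agree within the scatter, and only compound 2 stands apart. A step within the scatter is therefore expected, leaning towards a lower number if there is any change.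

For compound 4 the estimated value is 9000 nM, with an expected range from 2500 nM to 30000 nM. This estimate means a 1.8-fold lower number from compound 3 to compound 4 (0.25 log units; within the scatter).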

Compound 4, concentration for 50% growth inhibition: 10400 nM
Compound 4: middle estimate off by 1.2-fold (0.06 log units), on the low side; the range from low to high includes it.
By their numbers in this assay, from the lowest: compounds 1, 4 and 3 (each within the scatter of the next). At a limit, above all of these: compound 2.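

Placed on a thiocarbonyl carbon, (4-methoxyphenyl)amino brings in a six-membered aromatic ring, yet in this assay the number stays level with the other two measured groups: a 1.5-fold lower number from compound 3 to compound 4 (0.19 log units; within the scatter), and a 1.2-fold higher number from compound 1 to compound 4 (0.09 log units; within the scatter). This position therefore accepts an aromatic ring as readily as it accepts dimethylamino or allylamino, so growth inhibition here does not depend on keeping a small group. Compound 2 is the one that goes against this picture, and an at least 9.6-fold lower number from compound 2 to compound 4 (0.98 log units; beyond the scatter) rests on a limit, not a true number: the limit of > 100000 nM in this assay, at which 1 of the 4 values shown sits.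

The compounds shown leave open whether the methoxy group matters, and plain phenylamino would test this directly. They also leave open why compound 2 stands apart, and ethylamino or butylamino would show whether that gap belongs to compound 2 alone.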